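Adding a Second Methoxy to a Strong Kinase Inhibitor

The source may hold more compounds than are shown below. What is called first, only, known or untested is meant among the compounds shown, and "the series" means these compounds.

Of the compounds shown here, three sharing one core have been tested in an assay on isolated protein for inhibition of Death-associated protein kinase 3 (Homo sapiens), tested at 1 uM; on this read-out lower numbers stand for a weaker effect and higher numbers for a stronger effect at the one concentration tested. Compound 1 `COc1cccc(C2=N/C(=C\c3cccnc3)C(=O)O2)c1` gives 99% and stands highest of the three; compound 2 `O=C1OC(c2cccc(Br)c2)=N/C1=C\c1ccncc1` gives 1%, a number far below it and beyond the scatter, and compound 3 `O=C1OC(c2cccc([N+](=O)[O-])c2)=N/C1=C\c1ccncc1` gives 0%, further still. Within the data shown here, the only single-point step among the measured compounds, a number 1 percentage points lower from compound 2 to compound 3 (within the scatter), compares two compounds that both sit at the bottom of the scale and concerns a different change, so it says nothing about what happens near the top.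

Compound 4 `COc1ccc(C2=N/C(=C\c3cccnc3)C(=O)O2)cc1OC` has not been measured. It differs from compound 1 by methoxy in place of hydrogen on an aromatic carbon, the new group sitting on the aromatic ring ortho to the methoxy already present and para to a large group. Among the measured compounds shown here, no measured pair shows this kind of change. Compound 1 already lies close to the ceiling of this assay, so there is little room for an upward step; the open question is whether the added group costs anything. With nothing to indicate a loss, compound 4 is expected to stay high, with a number 9 percentage points lower from compound 1 to compound 4 (within the scatter) treated as within the scatter, while the range below is left wide for the lack of any guiding step. The estimate for compound 4 is 90%, with a range from 45% to 100%.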

Compound 4, a percentage reported as inhibition, at one concentration (the size of the read-out at that concentration, not a potency): 14%
Compound 4: the middle estimate sits 76 percentage points above what was measured, outside the stated range (below it).
By their numbers in this assay, from the lowest: compounds 3 and 2 (each within the scatter of the next); then compound 4; then compound 1.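

In this assay, one methoxy in place of hydrogen, on the aromatic ring ortho to the methoxy already present and para to a large group, gives a number 85 percentage points lower from compound 1 to compound 4 (beyond the scatter) and takes the reading from near the top of the scale to near the bottom. This spot on the ring is therefore not free to change, and the high reading of compound 1 proves sensitive to a group of only 2 heavy atoms. Among these compounds, the earlier compounds could not show this, as their one single-place step lay at the bottom of the scale, where a further loss would hardly register. Nothing in the available data accounts for the drop, and its cause remains unknown.

On these data alone, whether fluorine, a hydroxyl group or a longer chain such as ethoxy at this same spot would keep the reading high or lose it as well remains open. Also open, as far as these compounds go, is whether the loss depends on the methoxy already on the ring, or whether the new methoxy would do the same on a ring without it.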